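A few compounds are considered here, and "the series" means these few. Any claim that something is new, unique, unknown or untested is made for them only; others in the source may bear on it.

Measured compounds:
compound 1 `Cc1nc(N)c2c(-c3ccco3)cn([C@@H]3O[C@H](CO)[C@@H](O)[C@H]3O)c2n1`
compound 2 `COc1nc(N)nc2c1c(-c1ccoc1)cn2[C@@H]1O[C@H](CO)[C@@H](O)[C@H]1O`
compound 3 `Cc1nc(N)c2c(-c3ccoc3)cn([C@@H]3O[C@H](CO)[C@@H](O)[C@H]3O)c2n1`

In a functional assay on HeLa S3 cells (Homo sapiens) for antiproliferative activity, read by XTT assay, with a stated time of 72 h (a higher number here means a weaker inhibitor, a lower number a stronger inhibitor), compound 1 gives > 20000 nM, which is a limit of the assay rather than a number. In this assay compound 2 gives > 20000 nM, again a limit. Compound 3 gives > 20000 nM in this assay, also a limit. The change from compound 3 to compound 1 is furan-2-yl in place of furan-3-yl on an aromatic carbon, and its step that the two limits leave unreadable from compound 3 to compound 1 cannot be read, because of the limit of > 20000 nM in this assay, at which 3 of the 3 values shown sit. The difference between the cores of compound 2 and compound 3 is not broken down here. The unmeasured compound 4 `COc1nc(N)nc2c1c(-c1ccco1)cn2[C@@H]1O[C@H](CO)[C@@H](O)[C@H]1O` arises from compound 2 by furan-2-yl in place of furan-3-yl on an aromatic carbon, the same change as from compound 3 to compound 1. Since that earlier step is unreadable, the step from compound 2 to compound 4 is expected to be about a step that the limit leaves unreadable from compound 2 to compound 4. Compound 4 is therefore estimated at 30000 nM, with a range of 12000 nM to 100000 nM, most likely reported as a limit.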

Compound 4, half-maximal inhibitory concentration: > 20000 nM
Compound 4: no number, only a limit (the forecaster's own chance of this, stated with the estimate: 85%); the middle value is on the limit's open side.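

No new step can be read from compound 2 to compound 4, because both values are limits and not numbers: the limit of > 20000 nM in this assay, at which 4 of the 4 values shown sit.

The compounds shown leave open whether furan-2-yl and furan-3-yl differ at all in this assay, on either core.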